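Capping the Amine Nitrogen: Expected Cytotoxicity of Compound 4

The source may hold more compounds than are shown below. What is called first, only, known or untested is meant among the compounds shown, and "the series" means these compounds.

Of the compounds shown here, three sharing one core have been tested in an ADME assay on MT4 cells (Homo sapiens) for cytotoxicity, read by MTT assay, with a stated time of 96 h; on this read-out lower numbers stand for higher toxicity in this test and higher numbers for lower toxicity in this test. Compound 1 `O=C(CN1CCCCC1)Nc1ccc(-c2nc3cc(Cl)c(Cl)cc3[nH]2)cc1` carries a ((piperidin-1-yl)methyl)carbonyl group on the ring nitrogen and gives 54000 nM. Compound 2 `O=[N+]([O-])c1ccc(-c2nc3cc(Cl)c(Cl)cc3[nH]2)cc1` bears a nitro group and gives 17000 nM. Compound 3 `Nc1ccc(-c2nc3cc(Cl)c(Cl)cc3[nH]2)cc1` bears a free amino group and gives 17000 nM. Compound 3 thus sits level with compound 2, and the pair give the lowest numbers of the three, while compound 1 gives the highest.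

The two measured steps point in different directions in size. The step of no change at the digits printed from compound 2 to compound 3 (within the scatter) shows that swapping nitro for amino changed nothing. The step of a 3.2-fold lower number from compound 1 to compound 3 (0.50 log units; beyond the scatter) shows that stripping the larger acyl group from the nitrogen made the number fall by a modest amount.

Compound 4 `CC(=O)Nc1ccc(-c2nc3cc(Cl)c(Cl)cc3[nH]2)cc1` differs from compound 3 by acetyl in place of hydrogen on a nitrogen on an aromatic ring. This is the reverse sense of the step between compound 1 and compound 3, but with a much smaller group entering, so a smaller rise in this assay, if any, seems the fair expectation.

Compound 4 is therefore estimated at 28000 nM, with a range of 12000 nM to 70000 nM. The expected step then reads a 1.6-fold higher number from compound 3 to compound 4 (0.22 log units; within the scatter).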

Compound 4, half-maximal cytotoxic concentration: > 100000 nM
Compound 4 gave a limit, no number; the forecaster's own chance of this, stated with the estimate: 15%; middle value at least 3.5-fold (0.55 log units) from the limit.
By their numbers in this assay, from the lowest: compounds 2 and 3 (each within the scatter of the next); then compound 1. At a limit, above all of these: compound 4.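

Within the data shown here, the nitrogen on the aromatic ring turns out to be a sensitive place, although the earlier compounds showed only a modest change there and none on replacing nitro with amino. In this assay, adding just an acetyl group to this nitrogen gives an at least 5.8-fold higher number from compound 3 to compound 4 (0.76 log units; beyond the scatter), and replacing nitro with acetamido gives an at least 5.8-fold higher number from compound 2 to compound 4 (0.76 log units; beyond the scatter), so a small acyl group is enough to shift the read-out towards lower toxicity in this test. Removing the piperidin-1-yl group from the chain of the larger acyl group gives an at least 1.8-fold higher number from compound 1 to compound 4 (0.26 log units; that floor lies within the scatter), so the piperidine ring is not needed for a high number, though compound 1 and compound 4 are not clearly separated.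

The result for compound 4 is a limit of the assay and not a number, so the true size of these steps remains unknown: the limit of > 100000 nM in this assay, at which 1 of the 4 values shown sits.

From the compounds shown here alone, it also remains open whether the carbonyl matters or any group on this nitrogen would do, as a methyl group in place of acetyl would test, and whether a longer chain such as propanoyl or a benzoyl group would behave like acetyl.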